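The compounds below may be only part of what the source reports. "The series", "measured", "known", "first", "only" and "open" are said of these compounds alone.

Of the compounds shown here, three sharing one core have been measured. Compound 1 `CCCCNc1nc(N)nc2c1CN(C)CC2` gives, in an assay on HEK293 cells for agonist activity at Toll-like receptor 8 (Homo sapiens), read by a luciferase reporter, with a stated time of 6 h (a higher number here means that more compound is needed for the effect, a lower number that less compound is needed), a value of 0.03 uM. Compound 2 `CCCCNc1nc(N)nc2c1CCN(C)C2` has the same atoms as compound 1 joined differently; the difference between the two cores is not broken down here. In this assay compound 2 gives 0.2 uM. Compound 3 `CCCCNc1nc(N)nc2c1CN(C(C)=O)CC2` differs from compound 1 by a single change, (acetyl in place of methyl on an amine nitrogen in a ring), and in this assay compound 3 gives 0.5 uM. That change produced a 17-fold higher number from compound 1 to compound 3 (1.22 log units; beyond the scatter), a step clearly larger than the usual scatter of such measurements.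

Compound 4 `CCCCNc1nc(N)nc2c1CCN(C(C)=O)C2` has not been measured. It stands to compound 2 exactly as compound 3 stands to compound 1: the change is acetyl in place of methyl on an amine nitrogen in a ring, and the place it occurs is described in the same words in both cases, so this is the same change on a different core. Among the measured compounds shown here, the one precedent in the data is the step from compound 1 to compound 3, and it is the only guide to what the change does in this assay.

Taking that precedent as the basis, the expected step is a 10-fold higher number from compound 2 to compound 4 (1.00 log units; beyond the scatter), set beside the measured one from compound 1 to compound 3 because a 17-fold higher number from compound 1 to compound 3 (1.22 log units; beyond the scatter) is large. Since the core of compound 2 differs from that of compound 1 in a way that is not itemised here, the repetition is assumed rather than shown, and the estimate is held a little less extreme than a strict copy. Compound 4 is therefore expected to give about 2 uM in this assay, with a plausible range from 0.6 uM to 6 uM.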

Compound 4, minimum effective concentration: 0.4 uM
Compound 4: the middle estimate sits 5.0-fold (0.70 log units) above what was measured; measured number below the stated range.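

Acetyl in place of methyl on an amine nitrogen in a ring did not act alike on the two cores in this assay: the same change on two cores in this assay, a 17-fold higher number (1.22 log units; beyond the scatter) from compound 1 to compound 3 and a 2.0-fold higher number (0.30 log units; within the scatter) from compound 2 to compound 4, 8.3-fold (0.92 log units) apart, beyond the scatter of two such steps.

On the second core, the change gives a 2.0-fold higher number from compound 2 to compound 4 (0.30 log units; within the scatter) and so cannot be told apart from the ordinary spread of repeated measurements. The large step seen on the first core therefore cannot be assumed to travel with the change, even though the two cores hold the same atoms joined differently. Among the compounds shown here, what this does not show is why the cores part ways, or what the change would do on any further core, since each core offers only one such pair.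

The compounds shown leave open whether other groups on that ring nitrogen, such as ethyl, benzyl or a longer acyl chain, would also depend on the core in this way. They also leave open whether the same holds with a shorter or longer chain in place of the butyl chain.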